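Flavone analogues in a single-dose antiproliferative screen

The source may hold more compounds than are shown below. What is called first, only, known or untested is meant among the compounds shown, and "the series" means these compounds.

Compound 1 `COc1cc(OC)c2c(=O)cc(-c3ccc(OCCN4CCCC4=O)cc3)oc2c1`: 7%
Compound 2 `COc1cc(OC)c2c(=O)cc(-c3ccc(OC4CCNCC4)cc3)oc2c1`: "not active" (no number reported)
Compound 3 `COc1cc(OC)c2c(=O)cc(-c3ccc(-c4ccc(F)nc4)cc3)oc2c1`: "not active" (no number reported)

In a functional assay (Homo sapiens) for antiproliferative activity, read by resazurin assay, with a stated time of 48 h, tested at 5 uM (a higher number here means a stronger effect of the compound at the concentration tested, a lower number a weaker effect), compound 1 gives 7%, a small effect. Compound 2 is reported in this assay as "not active" (no number reported), with no number attached, and compound 3 is likewise given as "not active" (no number reported). Compound 2 therefore stands among the entries that carry no value at all; nothing places it above or below compound 1.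

Compound 4 `COc1cc(OC)c2c(=O)cc(-c3ccc(NCCN4CCCC4)cc3)oc2c1` differs from compound 2 in one place: (2-(pyrrolidin-1-yl)ethyl)amino in place of (piperidin-4-yl)oxy on an aromatic carbon. Among the compounds with values here, no step between measured compounds is available to judge this change, and compound 1, which carries a related chain, shows only a small effect. Compound 4 is therefore expected to give a weak read-out in this assay, estimated at 8% with a range of 0% to 25%, which may again be reported without a number.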

Compound 4, a percentage reported as inhibition, at one concentration (the size of the read-out at that concentration, not a potency): 21%
Compound 4: the middle estimate sits 13 percentage points below what was measured; low and high end bracket the measured number.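

In this assay, the read-out at this position, on an aromatic carbon para to a large group, now moves by a measurable amount: with (2-(pyrrolidin-1-yl)ethyl)amino in place of 2-(2-oxopyrrolidin-1-yl)ethoxy, the step is a number 14 percentage points higher from compound 1 to compound 4 (beyond the scatter). The change from compound 2 to compound 4 cannot be read, since compound 2 carries no number. Nothing on record explains the rise.

The step swaps the linking atom and the ring together, so neither is separated from the other. Going by these compounds, a piperidine or a morpholine on the same ethylamino chain, or a longer chain, remains open.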